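Compound 4 in a series resting at the limit

A few compounds are considered here, and "the series" means these few. Any claim that something is new, unique, unknown or untested is made for them only; others in the source may bear on it.

In a functional assay on RAW264.7 cells (Mus musculus) for inhibition, read by Griess assay, with stated times of 1 h and 24 h (a lower number here means a stronger inhibitor, a higher number a weaker inhibitor), compound 3 `COc1cc(OC)c2c(c1)C(C(O)c1ccc(OCCOc3ccccc3)cc1)OC2=O` gives > 10000 nM, a limit and not a number. Compound 1 `COc1cc(OC)c2c(c1)C(C(O)c1ccc(O)cc1)OC2=O` gives > 10000 nM, also a limit. Among the compounds with values here, compound 2 `CCCOc1ccc(C(O)C2OC(=O)c3c(OC)cc(OC)cc32)cc1` gives 9260 nM, the only actual number so far.

Compound 4 `COc1cc(OC)c2c(c1)C(C(O)c1ccc(OCc3ccc(C#N)cc3)cc1)OC2=O` differs from compound 3 by 4-cyanophenyl in place of phenoxymethyl on a saturated chain carbon bound to an oxygen on an aromatic ring, with 4-cyanophenyl in place of phenoxymethyl on a saturated chain carbon bound to an oxygen on an aromatic ring.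

Two measured steps at that oxygen bear on this: an at least 1.0-fold lower number from compound 1 to compound 2 (0.03 log units; that floor lies within the scatter) and an at least 1.0-fold higher number from compound 2 to compound 3 (0.03 log units; that floor lies within the scatter). The third is a step that the two limits leave unreadable from compound 1 to compound 3. On these steps, no change beyond the scatter is expected in this assay, and a further limit is likely.

The expected step is a number no higher from compound 3 to compound 4 (the limit leaves the size open). For compound 4 the estimate is 10000 nM, with an expected range of 4000 nM to 25000 nM.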

Compound 4, half-maximal inhibitory concentration: 7360 nM
Compound 4: middle estimate off by 1.4-fold (0.13 log units), on the high side, within the range that was stated.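

In this assay, 4-cyanobenzyl on this oxygen gives the series a second actual number, and against the propyl ether the reading is a 1.3-fold lower number from compound 2 to compound 4 (0.10 log units; within the scatter). Against the two limit compounds, the readings are an at least 1.3-fold lower number from compound 3 to compound 4 (0.13 log units; that floor lies within the scatter) and an at least 1.3-fold lower number from compound 1 to compound 4 (0.13 log units; that floor lies within the scatter). Compound 1 and compound 3 each stand at a limit, so these two steps remain floors: the limit of > 10000 nM in this assay, at which 2 of the 4 values shown sit.

From the compounds shown here alone, whether any group at this oxygen can move the number beyond the scatter remains open. An amine or a carboxylic acid in place of the nitrile would test this.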